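The source may hold more compounds than are shown below. What is called first, only, known or untested is meant among the compounds shown, and "the series" means these compounds.

In an ADME assay on RAW264.7 cells (Mus musculus) for cytotoxicity, read by WST assay (a lower number here means that less compound is tolerated, a higher number that more compound is tolerated), compound 1 `O=C(c1ccc(CN2Cc3ccccc3S2(=O)=O)cc1)N1CCCCC1` gives > 100000 nM, which is a limit of the assay. Compound 2 `O=C(c1ccc(CN2C(=O)c3ccccc3C2=O)cc1)N1CCCCC1` likewise gives > 100000 nM, again a limit of the assay. Compound 3 `CC(C)(C)OC(=O)c1ccc(CN2C(=O)c3ccccc3S2(=O)=O)cc1` gives > 100000 nM, also a limit of the assay; compound 3 therefore stands at the limit of > 100000 nM in this assay, at which 3 of the 3 values shown sit. Compound 4 `CN(C(=O)OC(C)(C)C)C(=O)c1ccc(CN2C(=O)c3ccccc3S2(=O)=O)cc1` differs from compound 3 by methyl(tert-butoxycarbonyl)amino in place of tert-butoxy on a carbonyl carbon. Among the measured compounds shown here, no step between measured compounds in this assay is available, and every value so far sits at the same limit. In this assay the expected step is a number no higher from compound 3 to compound 4 (the limit leaves the size open), none beyond the scatter. Compound 4 is estimated at 100000 nM, within 50000 nM to 200000 nM, and is expected most likely to be reported again only as a limit.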

Compound 4, concentration lethal to 50% of the cells: > 100000 nM
Compound 4: a limit, no number; the forecaster's own chance of this, stated with the estimate: 80%; the middle value lies on the limit itself.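

In this assay compound 4 gives > 100000 nM, a limit, so the step between compound 3 and compound 4 cannot be read. The compounds shown leave open how any structural change shifts the tolerated concentration, since all sit together: the limit of > 100000 nM in this assay, at which 4 of the 4 values shown sit.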